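The source may hold more compounds than are shown below. What is called first, only, known or untested is meant among the compounds shown, and "the series" means these compounds.

Measured compounds, in a functional assay on cells for agonist activity at Free fatty acid receptor 1 (Mus musculus), read by FLIPR and calcium flux, with a stated time of 100 s; a lower number here means that less compound is needed, a higher number that more compound is needed for the effect:
Compound 1 `Cc1ccccc1Oc1ccc(N2C[C@@H](C(F)(F)F)C[C@H]2CC(=O)O)cc1` gives 330 nM.
Compound 3 `Cc1ccccc1Oc1ccc(N2CCC[C@H]2CC(=O)O)cc1` gives 5600 nM.
Compound 2 `O=C(O)C[C@H]1CCN1c1ccc(OCc2ccc(Cl)cc2Cl)cc1` reaches only a limit of the assay, > 17000 nM.

Compound 1 stands lowest of the two numbers in this assay; the nearest number is that of compound 3, and the step of a 17-fold higher number from compound 1 to compound 3 (1.23 log units; beyond the scatter) sets that distance. Compound 2 sits at the limit of > 17000 nM in this assay, at which 1 of the 3 values shown sits, and gives no number. Compound 4 `Cc1ccccc1Cc1ccc(N2C[C@@H](C(F)(F)F)C[C@H]2CC(=O)O)cc1` differs from compound 1 in one place: 2-methylbenzyl in place of 2-methylphenoxy on an aromatic carbon. Going by the values given here, no measured step exchanges the link between the two aromatic rings; the only measured step, a 17-fold higher number from compound 1 to compound 3 (1.23 log units; beyond the scatter), concerns the trifluoromethyl on the saturated ring, which compound 4 keeps. Compound 2, which lacks that trifluoromethyl and has a different link between its aromatic rings, gives only a limit and so offers no number for the link itself. The step is therefore expected to be a 1.5-fold higher number from compound 1 to compound 4 (0.18 log units; within the scatter), smaller than the measured step and possibly within the scatter. Compound 4 is expected to give 500 nM in this assay, with a range from 150 nM to 2000 nM.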

Compound 4, half-maximal effective concentration: 710 nM
Compound 4: the middle estimate sits 1.4-fold (0.15 log units) below what was measured, and the stated range covers the measured number.
By their numbers in this assay, from the lowest: compound 1; then compound 4; then compound 3. At a limit, above all of these: compound 2.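

In this assay, going by these compounds alone, the step to 2-methylbenzyl on this aromatic carbon is a 2.2-fold higher number from compound 1 to compound 4 (0.33 log units; beyond the scatter) and is therefore a modest loss, the first measured change at this position. The 2-methylphenoxy group carries a hydrogen-bond acceptor and 2-methylbenzyl carries none, so in this pair the oxygen is not essential for a response in this assay, although replacing it has a small measurable cost. This change costs less than removal of the trifluoromethyl, where the step is a 17-fold higher number from compound 1 to compound 3 (1.23 log units; beyond the scatter) and is rated large, and nothing in the data gives a cause for the 2-methylbenzyl step.

As far as these compounds go, it remains open how a thioether or a carbonyl in place of the oxygen would compare with 2-methylphenoxy and 2-methylbenzyl. Also open, from the compounds shown here alone, is whether the cost of 2-methylbenzyl holds in compounds without the trifluoromethyl.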